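This account rests on a few compounds, and the source may have more. Where it says the series, first, only, none or still open, it means among the compounds named here.

Measured compounds:
compound 1, `COc1ccc(S(=O)(=O)c2cnc3cc(F)ccc3c2-c2ccc(Cl)cc2)cc1`, 1.28 mL/min
compound 2, `COc1cccc(-c2c(S(=O)(=O)c3cc(F)cc(F)c3)cnc3cc(F)ccc23)c1`, 1.81 mL/min
compound 3, `O=S(=O)(c1cc(F)cc(F)c1)c1cnc2cc(F)ccc2c1-c1cccc(Cl)c1`, 0.22 mL/min

In an ADME assay on microsomes from liver (Homo sapiens) for metabolic stability, tested at 2.5 uM (on this read-out higher numbers stand for fast clearance and lower numbers for slow clearance), the three measured compounds span a wide range. The one listed step, an 8.2-fold higher number from compound 3 to compound 2 (0.92 log units; beyond the scatter), comes from the change (methoxy in place of chloro on an aromatic carbon). Compound 1 and compound 3 share a core whose difference is not broken down here; their values show compound 1 with the higher number. Compound 4, `COc1ccc(-c2c(S(=O)(=O)c3ccc(OC)cc3)cnc3cc(F)ccc23)cc1`, is not yet measured. It arises from compound 1 by methoxy in place of chloro on an aromatic carbon, the same kind of change as that from compound 3 to compound 2, but here the group sits para to a large group rather than meta to it. Because the earlier step of an 8.2-fold higher number from compound 3 to compound 2 (0.92 log units; beyond the scatter) raised the number, compound 4 is expected to show a 2.0-fold higher number from compound 1 to compound 4 (0.29 log units; within the scatter) in this assay, though the different surroundings of the place leave the size uncertain. Compound 4 is therefore estimated at 2.5 mL/min, between 1 mL/min and 6 mL/min.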

Compound 4, intrinsic clearance in a liver preparation (reported as CLH), per the amount of preparation that the assay uses: 1.18 mL/min
Compound 4: the middle estimate sits 2.1-fold (0.33 log units) above what was measured, within the range that was stated.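

Going from 4-chlorophenyl to 4-methoxyphenyl gave a 1.1-fold lower number from compound 1 to compound 4 (0.04 log units; within the scatter) in this assay, so on this core the change has no readable effect. Set beside the earlier step, the same change clearly does not carry over from one core to the other with the same size: the same change on two cores in this assay, an 8.2-fold higher number (0.92 log units; beyond the scatter) from compound 3 to compound 2 and a 1.1-fold lower number (0.04 log units; within the scatter) from compound 1 to compound 4, 8.9-fold (0.95 log units) apart, beyond the scatter of two such steps

The two pairs differ in more than one respect, and they do not show which of those differences accounts for the gap, or how the change would behave on a further core. The compounds shown leave open what an amine or a carboxylic acid would do at this place in place of chloro. Also open, as far as these compounds go, is how a longer chain, such as ethoxy, would compare with methoxy on either core.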